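The source may hold more compounds than are shown below. What is called first, only, known or untested is meant among the compounds shown, and "the series" means these compounds.

Measured so far:
compound 1, `CO[C@]1(C)O[C@H]2[C@H](O)C=C(COC(C)=O)C(=O)[C@@H]2O[C@@]1(C)OC`: 16%
compound 2, `CO[C@@H]1C=C(COC(C)=O)C(=O)[C@H](O)[C@H]1O`: 23%

Both compounds were tested in an assay on isolated protein for inhibition of glutathione S-transferase P (Homo sapiens), read by spectrophotometry, with a stated time of 3 min, tested at 100 uM; a lower number here means less inhibition, a higher number more inhibition at the concentration tested (going by the name of the read-out). Compound 1 gives 16% there, and compound 2 gives 23%. The gap between the two numbers lies within the usual scatter of this kind of measurement, so compound 1 cannot be set apart from compound 2 on what is known; the two stand together at a modest level of inhibition at the concentration tested.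

Compound 3, `CO[C@@H]1C=C(COC(C)=O)C(=O)[C@@H]2O[C@@](C)(OC)[C@](C)(OC)O[C@@H]12`, is the next compound to be measured in this assay. Relative to compound 1 it carries one change: methyl in place of hydrogen on an oxygen on a saturated carbon.

Going by the values given here, no pair of measured compounds that differ in a single place is available, so there is no recorded step to lean on. Given how small the change is, the step of a number 2 percentage points higher from compound 1 to compound 3 (within the scatter) is expected to amount to no shift beyond the scatter, in either direction. Compound 3 is therefore expected to give 18% in this assay, with a plausible range from 5% to 35%.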

Compound 3, a percentage reported as inhibition, at one concentration (the size of the read-out at that concentration, not a potency): 38%
For compound 3 the middle estimate is 20 percentage points below the measured one, and the stated range ends below it.
By their numbers in this assay, from the lowest: compounds 1 and 2 (each within the scatter of the next); then compound 3.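

Going by these compounds alone, the one recorded change, methyl in place of hydrogen on an oxygen on a saturated carbon, gives a number 22 percentage points higher from compound 1 to compound 3 (beyond the scatter) in this assay, so this position is not indifferent to what sits on that oxygen. For this pair, the free hydroxy is not required for the inhibition seen at the concentration tested, and hydroxy to methoxy raises the number rather than lowering it. Nothing available bears on why the number moves with this change.

Going by these compounds, whether the rise belongs to the methyl alone or extends to other groups on that oxygen stays open, as an ethyl ether, an acetate ester or an amine in place of the hydroxy would show whether it continues, levels off or reverses. On these data alone, compound 3, at 38%, shows a stronger effect than compound 1 at the concentration tested, but it stays open how the two would compare at other concentrations, as these numbers are readings at a single concentration, and one pair cannot say whether the same change would give a similar step on a different core.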